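A few compounds are considered here, and "the series" means these few. Any claim that something is new, unique, unknown or untested is made for them only; others in the source may bear on it.

Measured so far in a functional assay on A549 cells (Homo sapiens) for cytotoxicity; on this read-out lower numbers stand for an effect already at smaller amounts and higher numbers for an effect only at larger amounts of compound:
compound 1, `C=CCCCCCCCC#CC#CC(O)CC(C)=O`, with 4.91 ug/mL
compound 2, `C=CCCCCCCCC#CC#CCO`, with 3.9 ug/mL

Among the measured compounds shown here, compound 2 shows the lowest of the two numbers recorded, but the only measured step, a 1.3-fold lower number from compound 1 to compound 2 (0.10 log units; within the scatter), lies inside the usual scatter, so compound 1 and compound 2 cannot be told apart on this read-out.

Compound 3, `C=CCCCCCCCC#CC#CCOCC(=O)O`, has not yet been measured. It differs from compound 2 in a single place: carboxymethyl in place of hydrogen on an oxygen on a saturated carbon.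

For the measured compounds named here, only one step bears on this at all. That step, a 1.3-fold lower number from compound 1 to compound 2 (0.10 log units; within the scatter), exchanged a group on a saturated chain carbon, not on the oxygen, and it stayed within the scatter. Going by the values given here, no measured pair shows carboxymethyl in place of hydrogen on an oxygen on a saturated carbon, so there is no direct precedent for the size or direction of the coming change.

The step expected from compound 2 to compound 3 is therefore a 1.2-fold higher number from compound 2 to compound 3 (0.06 log units; within the scatter), nothing beyond the scatter, though with a wide range of uncertainty. Compound 3 is estimated at 4.5 ug/mL, with a likely range from 1.8 ug/mL to 12 ug/mL.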

Compound 3, concentration for half-maximal effect: 6.26 ug/mL
Compound 3: middle estimate off by 1.4-fold (0.14 log units), on the low side, within the range that was stated.
By their numbers in this assay, from the lowest: compounds 2, 1 and 3 (each within the scatter of the next).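

In this assay, the oxygen on a saturated carbon of compound 2 is now shown to accept carboxymethyl without a readable change: the step is a 1.6-fold higher number from compound 2 to compound 3 (0.21 log units; within the scatter), and it is the first measured exchange made on this oxygen rather than on the saturated chain carbon. The end of the molecule can also be exchanged more broadly, since replacing 2-acetyl-1-hydroxyethyl with (carboxymethoxy)methyl on the triple-bonded carbon gives a 1.3-fold higher number from compound 1 to compound 3 (0.11 log units; within the scatter), so all three compounds remain indistinguishable on this read-out despite their different end groups. Nothing available explains why these exchanges leave the read-out within the usual scatter.

The compounds shown leave open whether a different group on this oxygen, such as an amine-bearing chain or the methyl ester of the carboxymethyl group, would produce a step beyond the scatter. They also leave open how much of the cytotoxicity depends on the shared core, for example whether a shorter chain in place of the long alkene-ending one would give a clearly different number.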